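The source may hold more compounds than are shown below. What is called first, only, known or untested is meant among the compounds shown, and "the series" means these compounds.

Of the compounds shown here, three of one shared core have been tested in an ADME assay on HCT-116 cells (Homo sapiens) for cytotoxicity, read by MTT assay; on this read-out higher numbers stand for lower toxicity in this test and lower numbers for higher toxicity in this test. Compound 1, with the structure `Cc1nc(-c2cccnc2)sc1-c1nnc(-c2cccnc2)o1`, gives in this assay only a limit of the assay, > 100 ug/mL. Compound 2, `COc1ccccc1-c1nnc(-c2sc(-c3cccnc3)nc2C)o1`, likewise gives only a limit in this assay, > 100 ug/mL. Compound 3, `Cc1ccccc1-c1nnc(-c2sc(-c3cccnc3)nc2C)o1`, also reaches only a limit in this assay, > 100 ug/mL. Compound 3 therefore stands where the other two stand: at the limit of > 100 ug/mL in this assay, at which 3 of the 3 values shown sit, so no number separates it from compound 1 or compound 2. The steps between them are accordingly unreadable: a step that the two limits leave unreadable from compound 1 to compound 2, a step that the two limits leave unreadable from compound 1 to compound 3 and a step that the two limits leave unreadable from compound 2 to compound 3.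

Compound 4, `Cc1nc(-c2cccnc2)sc1-c1nnc(-c2cccc(Cl)c2Cl)o1`, has not yet been measured in this assay. It differs from compound 3 in one place: 2,3-dichlorophenyl in place of 2-methylphenyl on an aromatic carbon. All three measured steps bear on this change in that each swapped the group at the same place of the core, and each left the read-out at the limit, so none of them shows a readable size. On that basis the expected step of a number no higher from compound 3 to compound 4 (the limit leaves the size open) is none beyond the scatter, with a fair chance that compound 4 again gives only a limit. The estimate for compound 4 in this assay is 100 ug/mL, within a range from 40 ug/mL to 200 ug/mL.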

Compound 4, half-maximal cytotoxic concentration: > 100 ug/mL
Compound 4 was reported as a limit; the forecaster's own chance of this, stated with the estimate: 65%; the middle value sits exactly at the limit.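

Among the compounds shown here, compound 4 gives only a limit in this assay, so no step between it and compound 1, compound 2 or compound 3 can be read, and all four compounds sit together: the limit of > 100 ug/mL in this assay, at which 4 of the 4 values shown sit. The compounds shown leave open how toxic any of them is to these cells, and whether any group at this place on the shared core would change the read-out.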